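A few compounds are considered here, and "the series" means these few. Any claim that something is new, unique, unknown or untested is made for them only; others in the source may bear on it.

Measured compounds:
compound 1 `COc1cc(N(C)CCN(C)C)c(NC(=O)/C=C\C(C)C)cc1Nc1nc(C)cc(-c2cn(C)c3ccccc23)n1` — 1230 nM
compound 2 `CCC/C=C\C(=O)Nc1cc(Nc2nc(C)cc(-c3cn(C)c4ccccc34)n2)c(OC)cc1N(C)CCN(C)C` — 254 nM
compound 3 `COc1cc(N(C)CCN(C)C)c(NC(=O)/C=C\C(C)C)cc1Nc1nccc(-c2cn(C)c3ccc(F)cc23)n1` — 7360 nM

All three numbers come from a functional assay on NCI-H1975 cells (Homo sapiens) for antiproliferative activity, read by MTT assay, with a stated time of 72 h; on this read-out lower numbers stand for stronger inhibition and higher numbers for weaker inhibition. Compound 1 and compound 2 share a core and differ in one place, (propyl in place of isopropyl on a double-bonded chain carbon bound to a double-bonded chain carbon); this gives a 4.8-fold lower number from compound 1 to compound 2 (0.69 log units; beyond the scatter). Compound 3 carries a different core; how its core differs from that of compound 1 is not broken down here. Compound 3 gives the highest number of the three, and its number is beyond the scatter from both compound 1 and compound 2.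

Compound 4 `CCC/C=C\C(=O)Nc1cc(Nc2nccc(-c3cn(C)c4ccc(F)cc34)n2)c(OC)cc1N(C)CCN(C)C` is not yet measured. For the measured compounds named here, it differs from compound 3 by propyl in place of isopropyl on a double-bonded chain carbon bound to a double-bonded chain carbon, which is the same change, at the same place, as the one from compound 1 to compound 2. Going by the values given here, for compound 4 a step of about the same size as a 4.8-fold lower number from compound 1 to compound 2 (0.69 log units; beyond the scatter) is expected, that is a 4.3-fold lower number from compound 3 to compound 4 (0.64 log units; beyond the scatter), resting on the single earlier instance of this change and on compound 3 giving 7360 nM. The expectation leans on one pair only, so the range is kept wide. Compound 4 is estimated at 1700 nM, between 600 nM and 5000 nM.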

Compound 4, half-maximal inhibitory concentration: 2730 nM
Estimate against measurement, compound 4: 1.6-fold (0.21 log units) below; the range from low to high includes it.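

In this assay, propyl in place of isopropyl on a double-bonded chain carbon bound to a double-bonded chain carbon gives a 2.7-fold lower number from compound 3 to compound 4 (0.43 log units; beyond the scatter) on the second core. Set beside the earlier instance, the step keeps its direction on both cores, and its size does not separate them: the same change on two cores in this assay, a 4.8-fold lower number (0.69 log units; beyond the scatter) from compound 1 to compound 2 and a 2.7-fold lower number (0.43 log units; beyond the scatter) from compound 3 to compound 4, 1.8-fold (0.25 log units) apart, within the scatter of two such steps. This supports carrying the change between these two cores in this assay, but two pairs in one cell line do not show that it holds on other cores, and they give no reason for the step.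

Still open, going by these compounds, is whether a longer chain, such as butyl or pentyl, or a cyclopropyl group in place of propyl would extend, keep or reverse the step. Also open, on these data alone, is whether a chain ending in an amine would fit the same trend on either core.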